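Moving a methoxy group on the series: working notes

The compounds below may be only part of what the source reports. "The series", "measured", "known", "first", "only" and "open" are said of these compounds alone.

Measured in an ADME assay on NHDF cells (Homo sapiens) for cytotoxicity, read by MTT assay, with a stated time of 72 h; on this read-out lower numbers stand for stronger inhibition and higher numbers for weaker inhibition:
- compound 1 `COc1ccc(/C=C2\CCC/C(=C\c3cccc(Br)c3)C2=O)cc1OC`: 12400 nM
- compound 2 `COc1ccc(/C=C2\CCC/C(=C\c3ccc(Br)cc3)C2=O)cc1OC`: 13100 nM
- compound 3 `COc1cccc(/C=C2\CCC/C(=C\c3ccc(OC)c(OC)c3)C2=O)c1`: 11600 nM

Compound 3 stands level with the other two measured compounds, with steps of a 1.1-fold lower number from compound 1 to compound 3 (0.03 log units; within the scatter) and a 1.1-fold lower number from compound 2 to compound 3 (0.05 log units; within the scatter). Compound 4 `COc1ccc(/C=C2\CCC/C(=C\c3ccc(OC)c(OC)c3)C2=O)cc1` differs from compound 3 by one change: 4-methoxyphenyl in place of 3-methoxyphenyl on a double-bonded chain carbon bound to a double-bonded ring carbon. Within the data shown here, the nearest precedent is 4-bromophenyl in place of 3-bromophenyl, which gave a 1.1-fold higher number from compound 1 to compound 2 (0.02 log units; within the scatter). The same kind of swap on the methoxyphenyl group has not been measured, so this single bromo pair carries the argument. The two steps that exchange bromo-bearing and methoxy-bearing groups also stay within the scatter. No step beyond the scatter is therefore expected in this assay, in either direction. The expected step is a 1.0-fold higher number from compound 3 to compound 4 (0.01 log units; within the scatter). For compound 4 the estimated value is 12000 nM, with an expected range of 7500 nM to 19000 nM.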

Compound 4, half-maximal inhibitory concentration: 30900 nM
Compound 4: the middle estimate sits 2.6-fold (0.41 log units) below what was measured, outside the stated range (above it).
By their numbers in this assay, from the lowest: compounds 3, 1 and 2 (each within the scatter of the next); then compound 4.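

In this assay, the place on a double-bonded chain carbon bound to a double-bonded ring carbon proves sensitive to where the methoxy sits: 4-methoxyphenyl in place of 3-methoxyphenyl gives a 2.7-fold higher number from compound 3 to compound 4 (0.43 log units; beyond the scatter), although the bromo pair showed no step beyond the scatter. Compound 4 also stands apart from both bromo compounds, with a 2.4-fold higher number from compound 2 to compound 4 (0.37 log units; beyond the scatter) and a 2.5-fold higher number from compound 1 to compound 4 (0.40 log units; beyond the scatter), and it is the only one of the four whose steps to all the others lie beyond the scatter. Methoxy in place of bromo on an aromatic carbon reads differently on the two cores, but that gap is not firm: the same change on two cores in this assay, a 1.1-fold lower number (0.03 log units; within the scatter) from compound 1 to compound 3 and a 2.4-fold higher number (0.37 log units; beyond the scatter) from compound 2 to compound 4, 2.5-fold (0.40 log units) apart, within the scatter of two such steps.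

Going by these compounds, whether this step depends on the rest of compound 4 remains open. Also open, on these data alone, is whether an ethoxy group or a dimethylamino group in place of that methoxy would follow compound 4 or compound 3.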